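Dimethoxy Variation on a Weaker Benzylidene Compound

The source may hold more compounds than are shown below. What is called first, only, known or untested is meant among the compounds shown, and "the series" means these compounds.

Compound 1, `COc1ccc(C=c2s/c(=C3\C(=O)Nc4cc(F)ccc43)n(CCN(C)C)c2=O)cc1`, was examined in a functional assay on NCI-H460 cells (Homo sapiens) for inhibition, read by MTT assay, with a stated time of 72 h (on this read-out lower numbers stand for stronger inhibition and higher numbers for weaker inhibition), where compound 1 gives 2200 nM. Among the two compounds with numbers in this assay, compound 1 stands highest; the other, compound 2, `CCN(CC)CCCn1c(=O)c(=Cc2ccc(O)cc2)s/c1=C1\C(=O)Nc2ccc(C)cc21`, gives 260 nM, a number lower by a margin that lies beyond the usual scatter of repeated measurements. Compound 2 also carries a different amine chain and a different substituent on the shared core, so the two values are not connected by any single change and only show where each one lies.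

Compound 3, `COc1ccc(OC)c(C=c2s/c(=C3\C(=O)Nc4cc(F)ccc43)n(CCN(C)C)c2=O)c1`, has not yet been measured. Its difference from compound 1 is 2,5-dimethoxyphenyl in place of 4-methoxyphenyl on a double-bonded chain carbon bound to an aromatic carbon. Within the data shown here, no measured pair in this set isolates such a change, so there is nothing in the data to anchor its direction. The step from compound 1 to compound 3 is therefore expected to be a 1.1-fold lower number from compound 1 to compound 3 (0.04 log units; within the scatter), which is no step beyond the scatter. Compound 3 is accordingly estimated at 2000 nM, with a range from 700 nM to 6000 nM in this assay.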

Compound 3, half-maximal inhibitory concentration: 7150 nM
Beside the measured number, compound 3's estimate is 3.6-fold (0.55 log units) below it, outside the stated range (above it).
By their numbers in this assay, from the lowest: compound 2; then compound 1; then compound 3.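

Among these compounds, until compound 3, no pair of compounds isolated anything at this position, so the aryl group on the double-bonded chain carbon bound to an aromatic carbon could have had no bearing on the number. In this assay the exchange of 4-methoxyphenyl for 2,5-dimethoxyphenyl gives a 3.3-fold higher number from compound 1 to compound 3 (0.51 log units; beyond the scatter) while the amine chain and the rest of the core of compound 1 stay the same, so this read-out does respond to the aryl group alone, and in this one pair the dimethoxy group goes with the weaker inhibition. The data offer no explanation for this shift, and nothing measured alongside these numbers bears on it.

Among the compounds shown here, the single step cannot separate the effect of gaining a methoxy group at the 2,5-positions of the name from that of losing the 4-methoxyphenyl pattern, and it gives no general trend for this place. As far as these compounds go, how an unsubstituted phenyl ring or a 4-chlorophenyl group would read at this place on the same core, with the same amine chain, remains open.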